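Benzyl thioethers on the shared core: outlook for compound 3

This account rests on a few compounds, and the source may have more. Where it says the series, first, only, none or still open, it means among the compounds named here.

Compound 1 `N#CCSc1nc2cc(Cl)c(Cl)cc2n1C1O[C@H](CO)[C@@H](O)[C@H]1O` carries a cyano on a saturated chain carbon bound to a sulfur. In a functional assay on KB cells (Homo sapiens) for inhibition (on this read-out higher numbers stand for weaker inhibition and lower numbers for stronger inhibition), compound 1 gives > 100000 nM, which is a limit of the assay rather than a number. Compound 1 thus stands at the weak end of the values shown, as the limit of > 100000 nM in this assay, at which 1 of the 2 values shown sits, records. Compound 2 `O=[N+]([O-])c1ccc(CSc2nc3cc(Cl)c(Cl)cc3n2C2O[C@H](CO)[C@@H](O)[C@H]2O)cc1` has 4-nitrophenyl in place of the cyano at that place, and in this assay compound 2 gives 30000 nM. Within the data shown here, the step of an at least 3.3-fold lower number from compound 1 to compound 2 (0.52 log units; beyond the scatter) is the only measured step and runs toward stronger inhibition.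

Among the measured compounds shown here, compound 3 `OC[C@H]1OC(n2c(SCc3cccc(C(F)(F)F)c3)nc3cc(Cl)c(Cl)cc32)[C@H](O)[C@@H]1O` is not yet measured. 3-(trifluoromethyl)phenyl in place of cyano on a saturated chain carbon bound to a sulfur The single measured step bears directly on this change: an aryl group entering on the saturated chain carbon bound to a sulfur, in place of cyano, gave an at least 3.3-fold lower number from compound 1 to compound 2 (0.52 log units; beyond the scatter). The same kind of change is made here, with 3-(trifluoromethyl)phenyl rather than 4-nitrophenyl, so a step of comparable size toward lower numbers in this assay is expected, an at least 3.3-fold lower number from compound 1 to compound 3 (0.52 log units; beyond the scatter). Compound 3 is therefore estimated at 30000 nM, within 8000 nM to 100000 nM.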

Compound 3, half-maximal inhibitory concentration: 15000 nM
Compound 3: the middle estimate sits 2.0-fold (0.30 log units) above what was measured; measured number inside the range.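

A second aryl group on the saturated chain carbon bound to a sulfur also moves the read-out toward stronger inhibition in this assay, with an at least 6.6-fold lower number from compound 1 to compound 3 (0.82 log units; beyond the scatter), so the gain over cyano at this place is no longer tied to 4-nitrophenyl alone. Between the two aryl groups there is no separation, with a 2.0-fold lower number from compound 2 to compound 3 (0.30 log units; within the scatter), so 3-(trifluoromethyl)phenyl and 4-nitrophenyl cannot be told apart here, although they sit on the ring in different printed positions. The step out of compound 1 can be read only as a bound, not as a size, because compound 1 is a limit of the assay and not a number: the limit of > 100000 nM in this assay, at which 1 of the 3 values shown sits.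

The compounds shown leave open whether the aromatic ring itself carries the gain at this place, or whether a longer alkyl chain, an amine or a carboxylic acid on the same carbon would give a comparable number. They also leave open where an unsubstituted phenyl would fall relative to compound 2 and compound 3.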